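Chloro for Methyl on a Second Core

This account rests on a few compounds, and the source may have more. Where it says the series, first, only, none or still open, it means among the compounds named here.

Compound 1 `Cc1ccc(-c2cc(/N=C/N(C)C)n(-c3ccc(Br)cc3)n2)cc1` and compound 2 `CN(C)/C=N/c1cc(-c2ccc(Cl)cc2)nn1-c1ccc(Br)cc1` share one core. In a functional assay on NCI-H226 cells (Homo sapiens) for inhibition, read by MTT assay, with a stated time of 72 h (a lower number here means a stronger inhibitor of growth, a higher number a weaker inhibitor of growth), compound 1 gives 73900 nM, and compound 2 gives 59800 nM. The change between them, (chloro in place of methyl on an aromatic carbon), produced a 1.2-fold lower number from compound 1 to compound 2 (0.09 log units; within the scatter). Compound 3 `Cc1ccc(-c2nn(-c3cccc(Cl)c3)c(N)c2C=O)cc1` is built on a different core; the difference between the two cores is not broken down here. In this assay compound 3 gives 71800 nM, which lies within the scatter of both compound 1 and compound 2. Compound 4 `Nc1c(C=O)c(-c2ccc(Cl)cc2)nn1-c1cccc(Cl)c1` has not yet been measured; it differs from compound 3 by chloro in place of methyl on an aromatic carbon, the same change as between compound 1 and compound 2, at a place described in identical words. Because a 1.2-fold lower number from compound 1 to compound 2 (0.09 log units; within the scatter) stayed within the scatter, a step of a 1.2-fold lower number from compound 3 to compound 4 (0.08 log units; within the scatter) is expected. Compound 4 is therefore estimated at 60000 nM in this assay, expected to fall between 25000 nM and 140000 nM.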

Compound 4, concentration for 50% growth inhibition: 79700 nM
Beside the measured number, compound 4's estimate is 1.3-fold (0.12 log units) below it; the range from low to high includes it.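

In this assay, chloro in place of methyl on an aromatic carbon gave a 1.1-fold higher number from compound 3 to compound 4 (0.05 log units; within the scatter). Set beside the earlier step, the change carried from one core to the other with no difference that can be told apart: the same change on two cores in this assay, a 1.2-fold lower number (0.09 log units; within the scatter) from compound 1 to compound 2 and a 1.1-fold higher number (0.05 log units; within the scatter) from compound 3 to compound 4, 1.4-fold (0.14 log units) apart, within the scatter of two such steps. This shows that 4-methylphenyl to 4-chlorophenyl left the number within the scatter on both cores, but it does not show that the change has any direction or size of its own, nor that the same would hold on a third core.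

The compounds shown leave open whether a carboxylic acid or a longer chain in that place would move the number beyond the scatter. They also leave open how this change would read in any other cell line.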